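Aziridinylquinone series: benzyl to aziridinyl step

The source may report more compounds than this note shows. Statements on the series, on what has been measured and on what is new or still open speak of the compounds shown alone.

Compound 1 `CC1=C(N2CC2)C(=O)C(Cc2ccccc2)=C(N2CC2)C1=O` is the weaker of the two measured compounds in a functional assay on L1210 cells (Mus musculus), with a stated time of 12 days; on this read-out higher numbers stand for higher potency (the scale is a negative logarithm) and lower numbers for lower potency: in this assay compound 1 gives 4.69, while compound 2 `CCC1=C(N2CC2)C(=O)C(CCOC(N)=O)=C(N2CC2)C1=O` gives 5.48, a gap beyond the usual scatter. Compound 3 `CC1=C(N2CC2)C(=O)C(N2CC2)=C(N2CC2)C1=O` has not yet been measured in this assay. It differs from compound 1 in one place: aziridin-1-yl in place of benzyl on a double-bonded ring carbon. Compound 3 is expected to gain in this assay, with a step from compound 1 of a number 0.91 log units higher from compound 1 to compound 3 (beyond the scatter), since the entering group matches those already present on the shared core. Compound 3 is thus estimated at 5.6, within 4.9 to 6.3.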

Compound 3, logarithm of the reciprocal of the active concentration, log(1/C): 6.21
Estimate against measurement, compound 3: 0.61 log units below; low and high end bracket the measured number.
By their numbers in this assay, from the lowest: compound 1; then compound 2; then compound 3.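

In this assay aziridin-1-yl in place of benzyl on a double-bonded ring carbon gives a number 1.52 log units higher from compound 1 to compound 3 (beyond the scatter) and shows that this position strongly affects the read-out on the core of compound 1. The entering group has 3 heavy atoms and the leaving group 7, so a large benzyl group is not needed here for potency. Nothing available explains the size of this step.

Going by these compounds, whether the gain needs the three-membered ring itself remains open. A dimethylamino group or a plain methyl at this carbon would test that, and an ethyl group in place of the methyl on the shared core would test the other side.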